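The source may hold more compounds than are shown below. What is called first, only, known or untested is meant among the compounds shown, and "the series" means these compounds.

Of the compounds shown here, three have numbers so far in a functional assay on HeLa cells (Homo sapiens) for inhibition, with a stated time of 72 h; a lower number here means that less compound is needed, a higher number that more compound is needed for the effect. Compound 1 (`COc1cc(CNCc2ccncc2)ccc1OCc1ccccc1F`) gives 5100 nM, compound 3 (`COc1cc(CNCCNc2ccnc3cc(Cl)ccc23)ccc1OCc1ccc(Cl)nc1`) gives 2700 nM, and compound 2 (`COc1cc(OCc2cnc(Cl)c(Cl)c2)ccc1CNCc1ccncc1`) gives 400 nM. Compound 1 thus sits with compound 3 at the upper end of these numbers, the two lying within the scatter of each other, while compound 2 has a clearly lower number, beyond the scatter from compound 1.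

Compound 4 (`COc1cc(CNCc2ccncc2)ccc1OCc1cnc(Cl)c(Cl)c1`) has not yet been measured. It keeps the core of compound 1 and exchanges one group, with 5,6-dichloropyridin-3-yl in place of 2-fluorophenyl on a saturated chain carbon bound to an oxygen on an aromatic ring.

Among the compounds with values here, no two measured compounds differ in one place only, so the data hold no direct precedent for this exchange. The closest guide is compound 2, which also carries the 5,6-dichloropyridin-3-yl group and gives 400 nM, although it differs from compound 4 elsewhere in the structure. On that indirect evidence a move to a lower number in this assay is expected, probably beyond the scatter but stopping short of compound 2. The expected step is a 4.6-fold lower number from compound 1 to compound 4 (0.67 log units; beyond the scatter). For compound 4 the estimated value is 1100 nM, with an expected range from 350 nM to 3500 nM.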

Compound 4, half-maximal effective concentration: 220 nM
Estimate against measurement, compound 4: 5.0-fold (0.70 log units) above; the measured number lies below the stated range.
By their numbers in this assay, from the lowest: compounds 4 and 2 (each within the scatter of the next); then compounds 3 and 1 (each within the scatter of the next).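

In this assay, putting 5,6-dichloropyridin-3-yl in place of 2-fluorophenyl on a saturated chain carbon bound to an oxygen on an aromatic ring gives a 23-fold lower number from compound 1 to compound 4 (1.37 log units; beyond the scatter). Within the data shown here, this is the first comparison here in which only one place differs, and it shows that, on the core of compound 1, the group at this position can by itself move the number by a large step, which the earlier compounds, differing in more than one place, could not show. The exchange alters the ring and its substituents together, with a ring nitrogen and two chlorines entering as the fluorine leaves, and nothing measured here offers an explanation for the step.

The compounds shown leave open which of these features carries the step, a question that an unsubstituted phenyl, an unsubstituted pyridin-3-yl or a dichlorophenyl at this place would address. Among these compounds, they also leave open whether the same exchange would give a step of similar size on a core with a different amine side chain, since this single pair is the only direct comparison available.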